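The source may hold more compounds than are shown below. What is called first, only, known or untested is meant among the compounds shown, and "the series" means these compounds.

Measured compounds in an assay on isolated protein for displacement of a labelled ligand from melanin-concentrating hormone receptor 1 (Homo sapiens); on this read-out lower numbers stand for stronger inhibition and higher numbers for weaker inhibition:

compound 1 `CC(C)N(C)c1ccc2cc(NC(=O)CCc3ccc(C(F)(F)F)cc3)ccc2n1` gives 2 nM
compound 2 `CCN(CC)c1ccc2cc(NC(=O)CCc3ccc(C(F)(F)F)cc3)ccc2n1` gives 88 nM
compound 3 `Nc1ccc2cc(NC(=O)CCc3ccc(C(F)(F)F)cc3)ccc2n1` gives 240 nM

Compound 3 stands highest of the three, meaning it is the weakest binder here: compound 2 sits a 2.7-fold higher number from compound 2 to compound 3 (0.44 log units; beyond the scatter) apart from it, and compound 1 lies furthest away, a 120-fold higher number from compound 1 to compound 3 (2.08 log units; beyond the scatter).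

Compound 4 `O=C(CCc1ccc(C(F)(F)F)cc1)Nc1ccc2nc(N3CC4CC3CO4)ccc2c1` is the next step from compound 3. The change is a group of 7 heavy atoms (5 carbon, 1 nitrogen, 1 oxygen; 2 five-membered non-aromatic rings with 1 hetero atom each) in place of one nitrogen atom, on an aromatic carbon.

Within the data shown here, two measured steps bear on this. Going from the amino group of compound 3 to the diethylamino group of compound 2 gave a 2.7-fold higher number from compound 2 to compound 3 (0.44 log units; beyond the scatter) read in reverse, a modest gain, while going to the isopropyl(methyl)amino group of compound 1 gave a 120-fold higher number from compound 1 to compound 3 (2.08 log units; beyond the scatter) in reverse, a large gain. Both show that replacing the plain amino group with a larger, fully substituted nitrogen lowers the number. The new bicyclic group of compound 4 is also a fully substituted nitrogen, so a clear drop is expected for compound 4, estimated as a 20-fold lower number from compound 3 to compound 4 (1.30 log units; beyond the scatter), with the exact size uncertain since neither measured step carries a ring. Compound 4 is therefore expected to reach about 12 nM in this assay, within a range from 2 nM to 70 nM.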

Compound 4, half-maximal inhibitory concentration: 13 nM
Compound 4: middle estimate off by 1.1-fold (0.03 log units), on the low side, within the range that was stated.
By their numbers in this assay, from the lowest: compound 1; then compound 4; then compound 2; then compound 3.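

In this assay, a nitrogen carrying two five-membered non-aromatic rings and an oxygen proves well accepted on this aromatic carbon next to the ring nitrogen, far better than the plain amino group (an 18-fold lower number from compound 3 to compound 4 (1.27 log units; beyond the scatter)). Compared with the two open-chain groups, the new group gives a mixed result: it beats the diethylamino group (a 6.8-fold lower number from compound 2 to compound 4 (0.83 log units; beyond the scatter)) but falls short of the isopropyl(methyl)amino group (a 6.5-fold higher number from compound 1 to compound 4 (0.81 log units; beyond the scatter)), so among these four compounds, the heavy-atom count of the group does not set the order, and compound 4, with the largest group, lands in the middle of the two groups of equal count. No measurement is available here that accounts for these differences.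

Still open, from the compounds shown here alone, is what a pyrrolidine, with the nitrogen in a single five-membered ring and no oxygen, would give, a comparison that could begin to separate the contribution of the oxygen from that of the second ring. Also open, going by these compounds, is whether a morpholine or a dimethylamino group in this place would come close to compound 1 or stay nearer to compound 4.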